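The source may hold more compounds than are shown below. What is called first, only, known or untested is meant among the compounds shown, and "the series" means these compounds.

Measured so far in a functional assay on QGY-7703 cells (Homo sapiens) for cytotoxicity, read by MTT assay, with a stated time of 24 h; on this read-out higher numbers stand for weaker inhibition and lower numbers for stronger inhibition:
- Compound 1 `CC(=O)Nc1ccc(S(=O)(=O)N2C/C(=C\c3ccccc3F)C(=O)/C(=C/c3ccccc3F)C2)cc1`: 5500 nM
- Compound 2 `COc1cc(/C=C2\CN(S(=O)(=O)c3ccc(F)cc3)C/C(=C\c3ccccc3F)C2=O)cc(OC)c1OC`: 13300 nM
- Compound 3 `CC(=O)Nc1ccc(S(=O)(=O)N2C/C(=C\c3ccc(C#N)cc3)C(=O)/C(=C/c3ccccc3F)C2)cc1`: 2050 nM

Of these three, compound 3 has the lowest number, 2050 nM, and so the strongest inhibition in this assay. Compound 1 lies nearest to it, while compound 2 lies furthest away at 13300 nM.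

Within the data shown here, the next compound, compound 4 `COc1cc(/C=C2\CN(S(=O)(=O)c3ccc(NC(C)=O)cc3)C/C(=C\c3ccccc3F)C2=O)cc(OC)c1OC`, has no measurement yet. It differs from compound 3 in one place: 3,4,5-trimethoxyphenyl in place of 4-cyanophenyl on a double-bonded chain carbon bound to a double-bonded ring carbon. In words, 3,4,5-trimethoxyphenyl stands in place of 4-cyanophenyl.

Among the measured compounds shown here, one measured step bears directly on this place: a 2.7-fold lower number from compound 1 to compound 3 (0.43 log units; beyond the scatter). That modest step came with the arrival of 4-cyanophenyl, the group that compound 4 gives up, so the lower number may not carry over. Compound 2 offers a looser guide. It carries 3,4,5-trimethoxyphenyl and gives 13300 nM, but it also differs from compound 4 elsewhere in the structure. For the measured compounds named here, no measured step isolates the effect of 3,4,5-trimethoxyphenyl alone, so the expectation is uncertain.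

A modest move towards a higher number is expected, meaning weaker inhibition: a 2.4-fold higher number from compound 3 to compound 4 (0.39 log units; beyond the scatter). The estimated value for compound 4 is 5000 nM, with an expected range from 1800 nM to 13000 nM.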

Compound 4, half-maximal inhibitory concentration: 2680 nM
Compound 4: middle estimate off by 1.9-fold (0.27 log units), on the high side, within the range that was stated.
By their numbers in this assay, from the lowest: compounds 3 and 4 (each within the scatter of the next); then compound 1; then compound 2.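

In this assay, putting 3,4,5-trimethoxyphenyl in place of 4-cyanophenyl on this chain carbon gives a 1.3-fold higher number from compound 3 to compound 4 (0.12 log units; within the scatter) and so leaves no difference that can be told from scatter, even though the two groups share little beyond their aromatic ring. Set against 2-fluorophenyl at the same place, the new group gives a 2.1-fold lower number from compound 1 to compound 4 (0.31 log units; beyond the scatter) and the earlier nitrile-bearing group gave a 2.7-fold lower number from compound 1 to compound 3 (0.43 log units; beyond the scatter) as well, so the lower number seen at this place does not depend on the nitrile. The high number of compound 2 also turns out not to come from 3,4,5-trimethoxyphenyl, since acetamido in place of fluoro on an aromatic carbon gives a 5.0-fold lower number from compound 2 to compound 4 (0.70 log units; beyond the scatter) with that group kept, and this is the largest of the single-place steps shown here.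

Still open, going by these compounds, is whether a 4-aminophenyl or 4-carboxyphenyl group at this place, or an amine in place of the acetamido group, would keep the number as low. Nothing among the data shown explains why these changes have the effects they do.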